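The source may hold more compounds than are shown below. What is called first, only, known or untested is meant among the compounds shown, and "the series" means these compounds.

Measured so far in a functional assay on A549 cells (Homo sapiens) for antiproliferative activity, read by MTT assay, with a stated time of 72 h; on this read-out lower numbers stand for stronger inhibition and higher numbers for weaker inhibition:
Compound 1 `COc1cc(-c2ncnn2-c2cccc(F)c2)cc(OC)c1OC` gives > 10000 nM as a limit of the assay
Compound 2 `COc1cccc(-c2ncnn2-c2cc(OC)c(OC)c(OC)c2)c1` gives > 10000 nM as a limit of the assay

Compound 2 stands at that limit and holds no number of its own. Within the data shown here, the series so far comes down to the limit of > 10000 nM in this assay, at which 2 of the 2 values shown sit, and nothing more.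

Compound 3 `COc1cc(-n2ncnc2-c2cccc(F)c2)cc(OC)c1OC` carries fluoro in place of methoxy on an aromatic carbon, meta to a large group, the change from 3-methoxyphenyl to 3-fluorophenyl fluoro in place of methoxy on an aromatic carbon relative to compound 2.

The expectation rests on compound 2, whose > 10000 nM is a limit. No step beyond the scatter is expected in this assay, in either direction, so the estimated step that the limit leaves unreadable from compound 2 to compound 3 stays small. Compound 3 is expected at 15000 nM within an estimated range of 4000 nM to 50000 nM and may well end up only as a limit.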

Compound 3, half-maximal inhibitory concentration: > 10000 nM
Compound 3: no number, only a limit (the forecaster's own chance of this, stated with the estimate: 75%); the middle value lies beyond the limit too.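

In this assay compound 3 gives > 10000 nM, a limit of the assay. Compound 2 also stands at a limit, so no step can be read between compound 2 and compound 3. Still open is whether fluoro in place of methoxy changes activity at all, as the series offers only this: the limit of > 10000 nM in this assay, at which 3 of the 3 values shown sit.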